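The source may hold more compounds than are shown below. What is called first, only, known or untested is meant among the compounds shown, and "the series" means these compounds.

Working notes on the benzylsulfanyl and alkylamino purine ribosides

Compound 1 `CCCCCNc1ncnc2c1ncn2[C@@H]1O[C@H](CO)[C@@H](O)[C@H]1O` gives 13500 nM in an assay on isolated protein for binding affinity to Equilibrative nucleoside transporter 1 (Homo sapiens); on this read-out higher numbers stand for weaker inhibition and lower numbers for stronger inhibition. Compound 2 `Cc1cccc(CSc2ncnc3c2ncn3[C@@H]2O[C@H](CO)[C@@H](O)[C@H]2O)c1` gives 12000 nM in this assay, and the pair differ only within the scatter: a 1.1-fold lower number from compound 1 to compound 2 (0.05 log units; within the scatter). Compound 3 `OC[C@H]1O[C@@H](n2cnc3c(CSc4ccccc4I)ncnc32)[C@H](O)[C@@H]1O` gives 282 nM in this assay, the lowest number of the three, with both steps to it beyond the scatter: a 48-fold lower number from compound 1 to compound 3 (1.68 log units; beyond the scatter) and a 43-fold lower number from compound 2 to compound 3 (1.63 log units; beyond the scatter). On these numbers compound 3 is the strongest inhibitor of the set.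

Compound 4 `OC[C@H]1O[C@@H](n2cnc3c(CSc4cccc(Br)c4)ncnc32)[C@H](O)[C@@H]1O` is not yet measured. It differs from compound 3 by 3-bromophenyl in place of 2-iodophenyl on a sulfur. The step that bears on it is a 43-fold lower number from compound 2 to compound 3 (1.63 log units; beyond the scatter), where a (3-methylbenzyl)sulfanyl group was exchanged for the 2-iodobenzyl sulfur group of compound 3. Compound 4 carries a 3-bromophenyl on the sulfur, so part of that large gain may be given back, though bromine and methyl are not the same group and no direct comparison exists. An upward step is therefore expected for compound 4, smaller than the full reversal: a 4.3-fold higher number from compound 3 to compound 4 (0.63 log units; beyond the scatter). Compound 4 is estimated at 1200 nM in this assay, within 250 nM to 6000 nM.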

Compound 4, half-maximal inhibitory concentration: 363 nM
Compound 4: the middle estimate sits 3.3-fold (0.52 log units) above what was measured; the range from low to high includes it.
By their numbers in this assay, from the lowest: compounds 3 and 4 (each within the scatter of the next); then compounds 2 and 1 (each within the scatter of the next).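

In this assay, 3-bromophenyl in place of 2-iodophenyl on the sulfur gives a 1.3-fold higher number from compound 3 to compound 4 (0.11 log units; within the scatter), so these two aryl groups cannot be told apart at this position, even though the halogen and its place on the ring both differ. Going by these compounds alone, the large steps from the earlier compounds therefore no longer rest on compound 3 alone: a 33-fold lower number from compound 2 to compound 4 (1.52 log units; beyond the scatter), and a 37-fold lower number from compound 1 to compound 4 (1.57 log units; beyond the scatter). No measurement here bears on the reason for these steps.

Since the halogen and its ring position change together between compound 3 and compound 4, the part played by each remains unresolved. Going by these compounds, it also remains open whether a halogen is needed at all, and whether a plain phenyl or a phenyl carrying an amine on the same sulfur would stay with compound 3 and compound 4 or fall back towards compound 2.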